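The source may report more compounds than this note shows. Statements on the series, on what has been measured and on what is new or still open speak of the compounds shown alone.

In a functional assay on DU-145 cells (Homo sapiens) for inhibition, read by trypan blue exclusion, with a stated time of 96 h (on this read-out lower numbers stand for stronger inhibition of growth and higher numbers for weaker inhibition of growth), compound 1 (`COc1ccccc1/C=C(/SCc1ccc(F)cc1)C(=O)c1ccc(Br)cc1`) gives 10000 nM, compound 2 (`COc1ccccc1/C=C(/SCc1ccc(Cl)cc1)C(=O)c1ccc(Cl)cc1`) gives 1000 nM and compound 3 (`COc1ccc(/C=C(/SCc2ccc(Cl)cc2)C(=O)c2ccc(Br)cc2)cc1`) gives 10000 nM. Compound 3 stands level with compound 1, the two sharing the highest number of the three, while compound 2 lies lower, beyond the scatter. Compound 4 (`COc1ccccc1/C=C(/SCc1ccc(Cl)cc1)C(=O)c1ccc(Br)cc1`) has 2-methoxyphenyl in place of 4-methoxyphenyl on a double-bonded chain carbon bound to a double-bonded chain carbon. Going by the values given here, the 2-methoxyphenyl group also occurs in compound 1 at 10000 nM and compound 2 at 1000 nM, so a modest step to a lower number is expected in this assay, although no measured pair isolates this change. The expected step is a 3.3-fold lower number from compound 3 to compound 4 (0.52 log units; beyond the scatter). The estimate for compound 4 is 3000 nM, with an expected range of 800 nM to 10000 nM.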

Compound 4, concentration for 50% growth inhibition: 1000 nM
Estimate against measurement, compound 4: 3.0-fold (0.48 log units) above, within the range that was stated.
By their numbers in this assay, from the lowest: compounds 2 and 4 (each within the scatter of the next); then compounds 1 and 3 (each within the scatter of the next).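

In this assay, going by these compounds alone, 2-methoxyphenyl in place of 4-methoxyphenyl on a double-bonded chain carbon bound to a double-bonded chain carbon gives a 10-fold lower number from compound 3 to compound 4 (1.00 log units; beyond the scatter), the first measured pair to isolate this change. With 2-methoxyphenyl held, chloro in place of fluoro on an aromatic carbon gives a 10-fold lower number from compound 1 to compound 4 (1.00 log units; beyond the scatter), while bromo in place of chloro on an aromatic carbon gives no change at the digits printed from compound 2 to compound 4 (within the scatter). Nothing on hand accounts for these steps. Still open, as far as these compounds go, is whether a hydroxyl or an amine in place of the methoxy keeps the number of compound 4. From the compounds shown here alone, whether the methoxy step holds with other halogen pairs is also open.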